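Swapping an Azide for a Vinyl Group: Expected Cytotoxicity

The source may report more compounds than this note shows. Statements on the series, on what has been measured and on what is new or still open speak of the compounds shown alone.

Compound 1, `CCCCCCCCCO[C@@H]1[C@@H](N)[C@@H](OCC(O)CNCCN)O[C@H](CN)[C@H]1OCCCCCCCCC`, gives 53% in a toxicity assay on the whole organism (J774 cells) for cytotoxicity, with Mus musculus as the target, read by MTT assay, with a stated time of 24 h, tested at 30 uM; a lower number here means a stronger effect, a higher number a weaker effect of the compound at the concentration tested.
Compound 2, `CCCCCCCCCO[C@@H]1[C@@H](N)[C@@H](O[C@H]2[C@H](O)[C@@H](OCCCCCCCCC)[C@H](N)C[C@@H]2N)O[C@H](CN)[C@H]1O`, gives 38.8%.
Compound 3, `CCCCCCCCCO[C@@H]1[C@@H](N)[C@@H](OC[C@H](O)CN=[N+]=[N-])O[C@H](CN)[C@H]1OCCCCCCCCC`, gives 5.9%.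

Compound 3 stands lowest of the three numbers in this assay, and both gaps lie beyond the scatter: compound 2 is the nearer of the other two, compound 1 the farther. Of the compound 3 series, the shared core carries two nonyl chains and two amines; the compounds differ in the side group attached through an oxygen on a saturated carbon.

Compound 4, `C=CCO[C@H]1O[C@H](CN)[C@@H](OCCCCCCCCC)[C@H](OCCCCCCCCC)[C@H]1N`, differs from compound 3 in one place: vinyl in place of 2-azido-1-hydroxyethyl on a saturated chain carbon bound to an oxygen on a saturated carbon. For the measured compounds named here, only one measured step touches this position, a number 47.1 percentage points lower from compound 1 to compound 3 (beyond the scatter), and it was large: bringing in the azide and hydroxyl pulled the number sharply down. Going by the values given here, compound 4 keeps neither of those, but no measured pair shows the bare vinyl, so the direction of its step is uncertain. Because compound 3 already gives 5.9%, a low number, the expected movement for compound 4 is upward, a number 12.1 percentage points higher from compound 3 to compound 4 (beyond the scatter), though of modest size. The estimate for compound 4 is 18%, with a range from 3% to 48%.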

Compound 4, a percentage reported as activity, at one concentration (the size of the read-out at that concentration, not a potency): 6.6%
Compound 4: middle estimate off by 11.4 percentage points, on the high side; the range from low to high includes it.
By their numbers in this assay, from the lowest: compounds 3 and 4 (each within the scatter of the next); then compound 2; then compound 1.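

In this assay the swap to vinyl reads a number 0.7 percentage points higher from compound 3 to compound 4 (within the scatter) even though 2-azido-1-hydroxyethyl, with 6 heavy atoms, a hydrogen-bond donor and hydrogen-bond acceptors, gives way to a group of 2 heavy atoms with no donor or acceptor. The azide and the hydroxyl are therefore not needed for the low number, which the step from compound 1 to compound 3 alone could not show. The comparison with compound 1 reads a number 46.4 percentage points lower from compound 1 to compound 4 (beyond the scatter) and places the large difference on the side of the 2-((2-aminoethyl)amino)-1-hydroxyethyl group, although no measurement shown here explains why the numbers fall as they do.

The compounds shown leave open which part of that 2-((2-aminoethyl)amino)-1-hydroxyethyl group goes with the higher number, the amines or the hydroxyl on the chain. A side group ending in a single primary amine, or one ending in a carboxylic acid, on the same oxygen of the shared core would be needed to tell whether the number follows the amines or simply any group other than vinyl or azide.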